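This account rests on a few compounds, and the source may have more. Where it says the series, first, only, none or still open, it means among the compounds named here.

Measured so far in a functional assay on the whole organism (Pleural cavity) with Rattus norvegicus as the target; on this read-out higher numbers stand for an effect only at larger amounts of compound and lower numbers for an effect already at smaller amounts:

Compound 1, `Clc1[nH]ccc2ncnc1-2`, gives only the limit > 9 mg/kg in this assay.
Compound 2, `CN(C)c1nccc2c1ncn2C1O[C@H](CO)[C@@H](O)[C@H]1O`, gives only the limit > 9 mg/kg in this assay.
Compound 3, `c1ccc(CSc2[nH]ccc3ncnc2-3)cc1`, gives only the limit > 9 mg/kg in this assay.

For compound 1 the measurement therefore stops at the edge of what the test could show, and the same is true of the two other compounds: the limit of > 9 mg/kg in this assay, at which 3 of the 3 values shown sit. Going by the values given here, no number is known for any of them, so no step between measured compounds can be stated, and no direction of change has yet been seen.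

Compound 4, `CSc1[nH]ccc2ncnc1-2`, is the compound still to be measured. It differs from compound 1 in a single place: methylsulfanyl in place of chloro on an aromatic carbon

With only limits to go on, the expected step that the limit leaves unreadable from compound 1 to compound 4 is set at none beyond the usual scatter, and a good chance remains that compound 4 will again give only a limit. The estimate for compound 4 in this assay is 15 mg/kg, with a range from 5 mg/kg to 50 mg/kg.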

Compound 4, dose for half-maximal effect: 9 mg/kg
For compound 4 the middle estimate is 1.7-fold (0.22 log units) above the measured one; measured number inside the range.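

In this assay, going by these compounds alone, compound 4 gives the first real number, so a readable effect is possible with a group on this aromatic carbon next to the ring nitrogen. Methylsulfanyl in place of chloro gives a number no higher from compound 1 to compound 4 (the limit leaves the size open). Compound 1 gives only a limit, > 9 mg/kg, so this change can be read only as a direction and its size cannot be read.

On these data alone, whether an amine, a methoxy group or a longer sulfur chain such as ethylsulfanyl on this same carbon would give an effect at smaller amounts stays open. With only one true number, the series offers no measured step of known size, and most of it still rests at the edge of the test: the limit of > 9 mg/kg in this assay, at which 3 of the 4 values shown sit.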